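Returning to a 4-carboxyphenyl with a fluorine

A few compounds are considered here, and "the series" means these few. Any claim that something is new, unique, unknown or untested is made for them only; others in the source may bear on it.

Compound 1, `COc1cc(C(=O)O)ccc1OCCCCOc1ccc(C(=O)CC(C)C)c(O)c1C`: 40 nM
Compound 2, `Cc1c(OCCCCOc2ccc(C(=O)O)c(Cl)c2)ccc(C(=O)CC(C)C)c1O`: 151 nM
Compound 3, `Cc1c(OCCCCOc2cccc(C(=O)O)c2)ccc(C(=O)CC(C)C)c1O`: 222 nM

In an assay on HEK293 cells for positive allosteric modulation of metabotropic glutamate receptor 2 (Rattus norvegicus), read by thallium flux, with a stated time of 2.5 min (a lower number here means that less compound is needed, a higher number that more compound is needed for the effect), compound 3 gives the highest of the three numbers; compound 2 lies within the scatter of it, while compound 1 lies lower by a margin beyond the scatter. Compound 4, `Cc1c(OCCCCOc2ccc(C(=O)O)cc2F)ccc(C(=O)CC(C)C)c1O`, differs from compound 3 in one place: 4-carboxy-2-fluorophenyl in place of 3-carboxyphenyl on an oxygen on a saturated carbon. The only measured step on the same position is a 1.5-fold higher number from compound 2 to compound 3 (0.17 log units; within the scatter), which stayed within the scatter, so moving between a 3-carboxyphenyl and a 4-carboxyphenyl carrying a halogen has so far shown no clear effect. Compound 1 also carries a 4-carboxy group but differs from compound 3 in two places, so its lower value cannot be assigned to that change alone. Compound 4 is therefore expected to give a 1.5-fold lower number from compound 3 to compound 4 (0.17 log units; within the scatter), a small step toward compound 2. The estimate for compound 4 is 150 nM, within 50 nM to 450 nM.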

Compound 4, half-maximal effective concentration: 102 nM
Estimate against measurement, compound 4: 1.5-fold (0.17 log units) above; the range from low to high includes it.
By their numbers in this assay, from the lowest: compound 1; then compounds 4, 2 and 3 (each within the scatter of the next, the first and the last beyond it).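

In this assay, within the data shown here, a 2.2-fold lower number from compound 3 to compound 4 (0.34 log units; beyond the scatter) is the first step at this position to pass beyond the scatter, so the 4-carboxy-2-fluorophenyl group now stands apart from the 3-carboxyphenyl group, though only modestly. Against the 4-carboxy-3-chlorophenyl group, the change gives a 1.5-fold lower number from compound 2 to compound 4 (0.17 log units; within the scatter), so those two halogen-bearing groups cannot be told apart. Fluoro in place of methoxy on an aromatic carbon gives a 2.6-fold higher number from compound 1 to compound 4 (0.41 log units; beyond the scatter), which ties the lower number of compound 1 to that single place.

Going by these compounds, it remains open whether a nitrile or a hydroxyl there would match the methoxy, or whether an amide could replace the carboxylic acid. Nothing given here explains these differences.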